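The compounds below may be only part of what the source reports. "The series", "measured", "known", "first", "only" and "open" are said of these compounds alone.

Measured so far, in a toxicity assay on HepG2 cells (Homo sapiens) for inhibition, read by CellTiter-Glo, with a stated time of 48 h; a higher number here means a weaker inhibitor, a lower number a stronger inhibitor:
Compound 1, `COc1ccc2nc(C)cc(OCC(=O)NCc3cc(C)cc(C)c3)c2c1`, gives only a limit of the assay, > 100000 nM.
Compound 2, `COc1ccc2nc(C)cc(OCC(=O)Nc3ccncc3)c2c1`, likewise gives only a limit, > 100000 nM.

Compound 2 therefore stands where every value so far stands, as shown by the limit of > 100000 nM in this assay, at which 2 of the 2 values shown sit. Within the data shown here, the one measured step, a step that the two limits leave unreadable from compound 1 to compound 2, runs from one limit to another, so its size cannot be read. Compound 3, `COc1ccc2nc(C)cc(OCC(=O)NC3CONC3=O)c2c1`, differs from compound 2 by a group of 6 heavy atoms (3 carbon, 1 nitrogen, 2 oxygen; one five-membered non-aromatic ring with 2 hetero atoms) in place of a group of 6 heavy atoms (5 carbon, 1 nitrogen; one six-membered aromatic ring with 1 hetero atom), on an amide-type nitrogen. Among the measured compounds shown here, no measured step resembles this change, and the single step available says nothing about how far such a swap on the amide nitrogen moves the value. The two limits give no hint that any change at this position brings the number down into the measurable range. Compound 3 is therefore expected to stay near the same limit, with a step that the limit leaves unreadable from compound 2 to compound 3 amounting to no step beyond the scatter. The estimate for compound 3 in this assay is 150000 nM, within a range from 60000 nM to 400000 nM.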

Compound 3, half-maximal inhibitory concentration: > 100000 nM
Compound 3 ended at the assay's limit (the forecaster's own chance of this, stated with the estimate: 85%); the middle value is on the limit's open side.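

No step among compound 1, compound 2 and compound 3 can be read in this assay, as each result is only a limit of the assay: the limit of > 100000 nM in this assay, at which 3 of the 3 values shown sit.

The compounds shown leave open whether any group on the amide-type nitrogen gives a readable value in this assay.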